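A few compounds are considered here, and "the series" means these few. Any claim that something is new, unique, unknown or untested is made for them only; others in the source may bear on it.

Compound 1 `COc1cc(OC)cc(-c2cc3ccccc3c(-c3cccc(O)c3)n2)c1` gives 840 nM in a functional assay on HCT-15 cells (Homo sapiens) for cytotoxicity, read by CCK-8 assay and cell counting, with a stated time of 72 h; on this read-out higher numbers stand for weaker inhibition and lower numbers for stronger inhibition. Compound 2 `COc1cc(OC)cc(-c2cc3ccccc3c(-c3cccc(OC)c3)n2)c1` gives 1170 nM. Compound 3 `COc1ccc(-c2cc3cc(C)ccc3c(-c3ccc(O)cc3)n2)cc1OC` gives 2520 nM.

Compounds 1 and 2 differ in one place, (methyl in place of hydrogen on an oxygen on an aromatic ring), and this change gave a 1.4-fold higher number from compound 1 to compound 2 (0.14 log units; within the scatter), a step within the usual scatter. Compound 3 stands apart from the other two: the difference between its core and that of compound 1 is not broken down here, and its value is the highest of the three, beyond the scatter from both.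

Compound 4 `COc1ccc(-c2nc(-c3ccc(OC)c(OC)c3)cc3cc(C)ccc23)cc1` is not yet measured. It arises from compound 3 by the same change, (methyl in place of hydrogen on an oxygen on an aromatic ring), at the same kind of place. Because the earlier step of a 1.4-fold higher number from compound 1 to compound 2 (0.14 log units; within the scatter) was small, the step from compound 3 is expected to be a 1.3-fold higher number from compound 3 to compound 4 (0.10 log units; within the scatter) in this assay. Compound 4 is therefore estimated at 3200 nM, between 1600 nM and 6500 nM.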

Compound 4, half-maximal inhibitory concentration: 28700 nM
Beside the measured number, compound 4's estimate is 9.0-fold (0.95 log units) below it; measured number above the stated range.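

In this assay, the change from hydroxy to methoxy did not carry over from one core to the other: the same change on two cores in this assay, a 1.4-fold higher number (0.14 log units; within the scatter) from compound 1 to compound 2 and an 11-fold higher number (1.06 log units; beyond the scatter) from compound 3 to compound 4, 8.2-fold (0.91 log units) apart, beyond the scatter of two such steps. On the core of compound 3, the change from 4-hydroxyphenyl to 4-methoxyphenyl gave an 11-fold higher number from compound 3 to compound 4 (1.06 log units; beyond the scatter), so the small step on the core of compound 1 is no guide to the size of the step on this core. The two pairs differ from each other in more than one place, so the data do not show which difference sets the size of the step, and two pairs establish no general rule.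

On these data alone, it remains open how an amine or an ethoxy group in place of that hydroxy would behave on the core of compound 3. Also open, as far as these compounds go, is how the same change would behave on further cores.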